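This account rests on a few compounds, and the source may have more. Where it says the series, first, only, none or still open, it means among the compounds named here.

Compound 1 `CC(C)CNC(=N)NC(=N)Nc1ccc(C(F)(F)F)cc1`: 2000 nM
Compound 2 `CC(C)CNC(=N)NC(=N)Nc1ccc(F)c(F)c1`: 7100 nM
Compound 3 `CCN(CC)C(=N)NC(=N)Nc1ccc(F)c(F)c1`: 22100 nM

All three were tested in a functional assay on UMUC3 cells (Homo sapiens) for antiproliferative activity, read by MTT assay, with a stated time of 72 h; a lower number here means a stronger inhibitor, a higher number a weaker inhibitor. Compound 1 gives 2000 nM, the lowest of the three numbers. Compound 2 gives 7100 nM, and compound 3 gives 22100 nM. The difference between the core of compound 1 and the core of compound 2 is not broken down here. Compound 2 and compound 3 differ by diethylamino in place of isobutylamino on a carbon with a double bond to nitrogen, and that change produced a 3.1-fold higher number from compound 2 to compound 3 (0.49 log units; beyond the scatter).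

Compound 4 `CCN(CC)C(=N)NC(=N)Nc1ccc(C(F)(F)F)cc1` has not yet been measured in this assay. It stands to compound 1 as compound 3 stands to compound 2, the change being (diethylamino in place of isobutylamino on a carbon with a double bond to nitrogen), made at the same place. Resting on a 3.1-fold higher number from compound 2 to compound 3 (0.49 log units; beyond the scatter), the expected step is a 3.1-fold higher number from compound 1 to compound 4 (0.49 log units; beyond the scatter). Compound 4 is therefore estimated at 6200 nM, most likely between 3000 nM and 13000 nM.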

Compound 4, half-maximal inhibitory concentration: 4900 nM
The estimate for compound 4 lay 1.3-fold (0.10 log units) above the measured number; the measured number falls inside the stated range.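

In this assay the same replacement of isobutylamino by diethylamino gave a 2.5-fold higher number from compound 1 to compound 4 (0.39 log units; beyond the scatter) on the core of compound 1, so the change ran in the same direction on both cores. The size of the step also carried over from one core to the other: the same change on two cores in this assay, a 3.1-fold higher number (0.49 log units; beyond the scatter) from compound 2 to compound 3 and a 2.5-fold higher number (0.39 log units; beyond the scatter) from compound 1 to compound 4, 1.3-fold (0.10 log units) apart, within the scatter of two such steps. This rests on two cores only and does not show why the number rises, or that the step would hold on other cores in the series.

The compounds shown leave open what a longer chain, such as hexylamino, or a cyclic amine, such as morpholine, would do in the same place. They also leave open whether the step would survive with a chlorine or a nitrile on the core in place of trifluoromethyl.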